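A few compounds are considered here, and "the series" means these few. Any claim that something is new, unique, unknown or untested is made for them only; others in the source may bear on it.

Compound 3 `COc1ccccc1Cc1cnc(CCc2ccc(-c3ccccc3C(=O)O)cc2)[nH]1` stands highest of the three numbers in an in vitro functional assay on cells for agonist activity at Bombesin receptor subtype-3 (Homo sapiens), read by luminescence and calcium flux; a higher number here means that more compound is needed for the effect, a lower number that less compound is needed: compound 3 gives 1720 nM, whereas compound 1 `O=C(O)c1ccccc1-c1ccc(CCc2ncc(CC3CCOCC3)[nH]2)cc1` gives 338 nM and compound 2 `O=C(O)c1ccccc1-c1ccc(CCc2ncc(CC3CCCC3)[nH]2)cc1` gives 133 nM. Both steps into compound 3 run uphill, namely a 5.1-fold higher number from compound 1 to compound 3 (0.71 log units; beyond the scatter) and a 13-fold higher number from compound 2 to compound 3 (1.11 log units; beyond the scatter), while a 2.5-fold lower number from compound 1 to compound 2 (0.41 log units; beyond the scatter) separates the two saturated rings from each other. Compound 4 `O=C(O)c1ccccc1-c1ccc(CCc2ncc(Cc3cccc(Cl)c3)[nH]2)cc1` is reached from compound 3 by 3-chlorophenyl in place of 2-methoxyphenyl on a saturated chain carbon bound to an aromatic carbon. Among the compounds with values here, no measured step swaps one aromatic ring for another, so an exchange of a six-membered aromatic ring with one acceptor for a six-membered aromatic ring with none rests on no direct precedent; the measured steps show only that compound 3 sits well above compound 1 and compound 2. For compound 4 a modest move toward the lower numbers is therefore expected, a 2.5-fold lower number from compound 3 to compound 4 (0.39 log units; beyond the scatter), with wide uncertainty. The estimate for compound 4 in this assay is 700 nM, within a range from 150 nM to 3000 nM.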

Compound 4, half-maximal effective concentration: 825 nM
Estimate against measurement, compound 4: 1.2-fold (0.07 log units) below; the range from low to high includes it.
By their numbers in this assay, from the lowest: compound 2; then compound 1; then compound 4; then compound 3.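

In this assay, within the data shown here, 3-chlorophenyl in place of 2-methoxyphenyl gives a 2.1-fold lower number from compound 3 to compound 4 (0.32 log units; beyond the scatter) and is the only step here that exchanges one aromatic ring for another, so the number at this position depends on what the ring carries and not only on the ring being aromatic. The chlorinated ring still does not reach the saturated rings: the change from cyclopentyl gives a 6.2-fold higher number from compound 2 to compound 4 (0.79 log units; beyond the scatter) and the change from oxan-4-yl gives a 2.4-fold higher number from compound 1 to compound 4 (0.39 log units; beyond the scatter) in the same direction. Among these four compounds, compound 3 and compound 4, with aromatic rings, both stand above compound 1 and compound 2, with saturated rings.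

Going by these compounds, it remains open how 3-methoxyphenyl or 2-chlorophenyl would stand, and so whether the step follows the change of group or its place on the ring. No measurement shown gives a reason for any of these differences.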